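Capping the hydroxy group of compound 3 with an epoxide

The source may hold more compounds than are shown below. What is called first, only, known or untested is meant among the compounds shown, and "the series" means these compounds.

Values in a functional assay on U-251 cells (Homo sapiens) for cytotoxicity; a higher number here means a weaker inhibitor of growth, a lower number a stronger inhibitor of growth:
compound 1 `CSc1ccc(C2=C(c3ccc(F)c(C)c3)C(=O)N3CCCC3C2)cc1`: 200 nM
compound 2 `COc1ccc(C2=C(c3ccc(SC)cc3)CC3CCCN3C2=O)cc1`: 2000 nM
compound 3 `CSc1ccc(C2=C(c3ccc(O)cc3)C(=O)N3CCCC3C2)cc1`: > 100000 nM (a limit, not a number)

Compound 3 stands at the limit of > 100000 nM in this assay, at which 1 of the 3 values shown sits, so it has a limit only. Compound 4 `CSc1ccc(C2=C(c3ccc(OCC4CO4)cc3)C(=O)N3CCCC3C2)cc1` carries (oxiran-2-yl)methyl in place of hydrogen on an oxygen on an aromatic ring.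

The closest measured change is an at least 50-fold higher number from compound 2 to compound 3 (1.69 log units; beyond the scatter), where hydrogen replaces methyl on that same oxygen. A wider view comes from an at least 500-fold higher number from compound 1 to compound 3 (2.69 log units; beyond the scatter), a large step, and a 10-fold higher number from compound 1 to compound 2 (1.00 log units; beyond the scatter), a modest one. Among these three compounds, only the free hydroxy compound sits at the limit. No (oxiran-2-yl)methyl compound has been measured yet, so compound 2 at 2000 nM is the best available guide, and the expected range stays wide. A large move to a lower number is expected, an at least 50-fold lower number from compound 3 to compound 4 (1.69 log units; beyond the scatter). For compound 4 the estimated value is 2000 nM, with an expected range of 300 nM to 15000 nM.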

Compound 4, concentration for 50% growth inhibition: 80 nM
Estimate against measurement, compound 4: 25-fold (1.40 log units) above; the whole stated range lies above it.
By their numbers in this assay, from the lowest: compound 4; then compound 1; then compound 2. At a limit, above all of these: compound 3.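

On the oxygen on the aromatic ring, (oxiran-2-yl)methyl gives an at least 1200-fold lower number from compound 3 to compound 4 (3.09 log units; beyond the scatter) in this assay, so the free hydroxy compound is not the ceiling of what this position can do. Compound 3 holds a limit and not a number: the limit of > 100000 nM in this assay, at which 1 of the 4 values shown sits. Oxiran-2-yl on the methyl of the ether gives a 25-fold lower number from compound 2 to compound 4 (1.40 log units; beyond the scatter) beyond the scatter, so in this assay the position takes a substituent larger than methyl, one carrying a three-membered ring, with a lower number.

Whether the oxirane ring itself or only the longer group on the oxygen accounts for this stays open, and a propyl chain or a cyclopropylmethyl group on the same oxygen would separate the two. Going by these compounds, how an amine or a carboxylic acid at the end of such a chain would read also remains open.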